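The source may report more compounds than this note shows. Statements on the series, on what has been measured and on what is new or still open speak of the compounds shown alone.

Going by the values given here, in a functional assay on K562 cells (Homo sapiens) for inhibition, read by trypan blue exclusion, with a stated time of 72 h (on this read-out higher numbers stand for weaker inhibition and lower numbers for stronger inhibition), compound 2 (`Cn1c(=O)c(S(=O)(=O)Nc2ccc(F)cc2)cc2cnc(Nc3ccc4[nH]ccc4c3)nc21`) gives 5000 nM, the higher of the two numbers so far, while compound 1 (`Cn1c(=O)c(S(=O)(=O)c2ccc(O)cc2)cc2cnc(Nc3ccc4[nH]ccc4c3)nc21`) gives 100 nM. Among the compounds with values here, the only measured step, a 50-fold higher number from compound 1 to compound 2 (1.70 log units; beyond the scatter), is large and beyond the scatter; it put (4-fluorophenyl)amino in place of 4-hydroxyphenyl on the sulfonyl sulfur. Compound 3 (`Cn1c(=O)c(S(=O)(=O)c2ccc(F)cc2N)cc2cnc(Nc3ccc4[nH]ccc4c3)nc21`) has 2-amino-4-fluorophenyl in place of (4-fluorophenyl)amino on that sulfur: 2-amino-4-fluorophenyl in place of (4-fluorophenyl)amino on a sulfonyl sulfur. Like compound 1 at 100 nM, it has an aromatic carbon on the sulfonyl sulfur, so a large step to a lower number is expected in this assay. The expected change is a 17-fold lower number from compound 2 to compound 3 (1.22 log units; beyond the scatter). For compound 3 the estimated value is 300 nM, with a range of 80 nM to 1500 nM.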

Compound 3, half-maximal inhibitory concentration: 2000 nM
Compound 3: middle estimate off by 6.7-fold (0.82 log units), on the low side; measured number outside the range, above it.
By their numbers in this assay, from the lowest: compound 1; then compound 3; then compound 2.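

In this assay, an aromatic carbon on the sulfonyl sulfur was not enough on its own to reach the level of compound 1: the change gave only a modest gain (a 2.5-fold lower number from compound 2 to compound 3 (0.40 log units; beyond the scatter)), and a large gap remains (a 20-fold higher number from compound 1 to compound 3 (1.30 log units; beyond the scatter)). The group on that sulfur therefore matters beyond the atom that joins it, as 2-amino-4-fluorophenyl and 4-hydroxyphenyl stand far apart. Nothing available explains this gap. Still open, as far as these compounds go, is how the number depends on the amine and the fluorine of 2-amino-4-fluorophenyl. From the compounds shown here alone, it is also open where a 4-aminophenyl or 4-methoxyphenyl group on that sulfur would fall.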